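Aryl amide variation on the naphthalenesulfonamide series

The source may report more compounds than this note shows. Statements on the series, on what has been measured and on what is new or still open speak of the compounds shown alone.

Measured so far:
compound 1 `CCCC(=O)N1CCC(NS(=O)(=O)c2ccc(NC(=O)C(CC)CC)c3ccccc23)CC1` 639 nM
compound 2 `CCCC(=O)N1CCC(NS(=O)(=O)c2ccc(NC(=O)c3cc(C)nc(Cl)c3)c3ccccc23)CC1` 43.9 nM

Compound 2 has the lowest number of the two in an in vitro functional assay on CHO/Galpha16 cells for antagonist activity at C-C chemokine receptor type 8 (Homo sapiens), read by FLIPR; on this read-out higher numbers stand for weaker inhibition and lower numbers for stronger inhibition; the step of a 15-fold lower number from compound 1 to compound 2 (1.16 log units; beyond the scatter) is the only one known. Compound 3 `CCCC(=O)N1CCC(NS(=O)(=O)c2ccc(NC(=O)c3cccnc3)c3ccccc23)CC1` differs from compound 2 by pyridin-3-yl in place of 2-chloro-6-methylpyridin-4-yl on a carbonyl carbon. Within the data shown here, no step among the measured compounds bears directly on this change; the step from compound 1 to compound 2 only shows that a ring on this carbonyl carbon gives a markedly lower number than pentan-3-yl. Compound 3 keeps a ring, so a modest rise is expected, a 3.4-fold higher number from compound 2 to compound 3 (0.53 log units; beyond the scatter). For compound 3 the expected value is 150 nM, range 45 nM to 500 nM.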

Compound 3, half-maximal inhibitory concentration: 885 nM
Beside the measured number, compound 3's estimate is 5.9-fold (0.77 log units) below it; measured number above the stated range.
By their numbers in this assay, from the lowest: compound 2; then compounds 1 and 3 (each within the scatter of the next).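

In this assay a ring on this carbonyl carbon is not enough on its own: pyridin-3-yl in place of 2-chloro-6-methylpyridin-4-yl gives a 20-fold higher number from compound 2 to compound 3 (1.30 log units; beyond the scatter) and, in place of pentan-3-yl, gives a 1.4-fold higher number from compound 1 to compound 3 (0.14 log units; within the scatter) with no separation from the open-chain amide. The low number of compound 2 therefore goes with the 2-chloro-6-methylpyridin-4-yl group specifically, not with any pyridine ring. Nothing available accounts for this difference.

Still open, as far as these compounds go, is whether the chlorine, the methyl or the ring attachment carries the difference. A 2-chloropyridin-4-yl or 2-methylpyridin-4-yl group would separate these.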